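Replacing 4-methoxyphenyl with (trifluoromethyl)carbonyl on the shared core

The compounds below may be only part of what the source reports. "The series", "measured", "known", "first", "only" and "open" are said of these compounds alone.

In a functional assay on HCT-116 cells (Homo sapiens) for antiproliferative activity, read by MTT assay, with a stated time of 48 h (a lower number here means a stronger inhibitor, a higher number a weaker inhibitor), compound 1 (`COc1ccc(-c2c(Nc3cc(OC)c(OC)c(OC)c3)c3ccc(OC)cc3oc2=O)cc1`) is recorded as "not determined" (no result reported) and so offers no number of its own as a starting point. The only measured figure in this small set belongs to compound 2 (`COc1ccc(-c2c(Nc3cc(OC)c(OC)c(OC)c3)c3ccc(O)cc3oc2=O)cc1`), which gives 64200 nM in the same test.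

Compound 3 (`COc1ccc2c(Nc3cc(OC)c(OC)c(OC)c3)c(C(=O)C(F)(F)F)c(=O)oc2c1`) departs from compound 1 at one place, with (trifluoromethyl)carbonyl in place of 4-methoxyphenyl on an aromatic carbon. That carbon belongs to a six-membered aromatic ring with 1 oxygen, and it lies two atoms from the ring oxygen. Going by the values given here, no measured pair shows what such an exchange does, so any forecast here is loose. With compound 2 at 64200 nM as the sole reference, a step toward a stronger inhibitor is expected in this assay, beyond the usual scatter but not a large one. Compound 3 is expected at 15000 nM with an estimated range from 3000 nM to 60000 nM on this read-out.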

Compound 3, half-maximal inhibitory concentration: 17000 nM
Compound 3: middle estimate off by 1.1-fold (0.05 log units), on the low side; low and high end bracket the measured number.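

Compound 1 carries no number in this assay, so the exchange that leads to compound 3 cannot be read as a step. The compounds shown leave open what replacing 4-methoxyphenyl with (trifluoromethyl)carbonyl does to activity on the shared core. Nothing given here bears on the result for compound 3.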